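Removing the ortho fluorine from a benzylthio triazole

This account rests on a few compounds, and the source may have more. Where it says the series, first, only, none or still open, it means among the compounds named here.

Compound 1, `Fc1ccccc1CSc1nnc(-c2ccncc2)n1-c1ccccc1`, is one of three measured members of this series. Among the measured compounds shown here, in a functional assay on MCF7 cells (Homo sapiens) for inhibition, read by MTT assay, with a stated time of 48 h (on this read-out lower numbers stand for stronger inhibition and higher numbers for weaker inhibition), compound 1 gives > 50000 nM, which is a limit of the measurement and not a number; it is the only one of the three values that stands at the limit of > 50000 nM in this assay, at which 1 of the 3 values shown sits. Compound 2, `Brc1cccc(CSc2nnc(-c3ccncc3)n2-c2ccccc2)c1`, gives 10000 nM in this assay, and compound 3, `Fc1ccc(CSc2nnc(-c3ccncc3)n2-c2ccccc2)cc1`, gives 21100 nM. Both measured steps out of compound 1 move the same way: an at least 5.0-fold lower number from compound 1 to compound 2 (0.69 log units; beyond the scatter), and an at least 2.3-fold lower number from compound 1 to compound 3 (0.37 log units; beyond the scatter). Compound 4, `c1ccc(CSc2nnc(-c3ccncc3)n2-c2ccccc2)cc1`, is not yet measured; it differs from compound 1 by hydrogen in place of fluoro on an aromatic carbon. The two measured steps only show that changing the 2-fluorophenyl gave a lower number, and neither removes the fluoro outright, so the expectation for compound 4 rests on a loose reading of them. Compound 4 is expected to give about 30000 nM in this assay, within 10000 nM to 100000 nM. That estimate corresponds to an expected at least 1.6-fold lower number from compound 1 to compound 4 (0.22 log units; that floor lies within the scatter).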

Compound 4, half-maximal inhibitory concentration: 22400 nM
The estimate for compound 4 lay 1.3-fold (0.13 log units) above the measured number; low and high end bracket the measured number.
By their numbers in this assay, from the lowest: compound 2; then compounds 3 and 4 (each within the scatter of the next). At a limit, above all of these: compound 1.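

In this assay, hydrogen in place of fluoro on the aromatic carbon gives an at least 2.2-fold lower number from compound 1 to compound 4 (0.34 log units; beyond the scatter), so moving away from the 2-fluorophenyl needs no new substituent for the number to fall. The size of that step is only a floor, since the value for compound 1 is a limit and not a number: the limit of > 50000 nM in this assay, at which 1 of the 4 values shown sits. The plain phenyl also serves as a reference for the other rings: the 4-fluorophenyl cannot be told from it, with a 1.1-fold higher number from compound 3 to compound 4 (0.03 log units; within the scatter), whereas the 3-bromophenyl can, with a 2.2-fold higher number from compound 2 to compound 4 (0.35 log units; beyond the scatter).

Going by these compounds, it remains open whether a methoxy group or an amine on the phenyl ring would bring the number below that of compound 2. Also open, on these data alone, is how a longer chain in place of the benzyl would read.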